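The source may hold more compounds than are shown below. What is called first, only, known or untested is meant among the compounds shown, and "the series" means these compounds.

Working notes on the series, read in a functional assay (Pituitary gland cell) with Rattus norvegicus as the target; a lower number here means that less compound is needed, a higher number that more compound is needed for the effect. Compound 1 (`CNC(=O)Nc1ccccc1-c1ccc(CN2C(=O)[C@H](NC(=O)CC(C)(C)N)CCc3ccccc32)cc1`) gives 50 nM, compound 2 (`CNC(=O)NCc1ccccc1-c1ccc(CN2C(=O)[C@H](NC(=O)C(C)(C)N)CCc3ccccc32)cc1`) gives 1 nM and compound 3 (`CC(C)(N)C(=O)N[C@@H]1CCc2ccccc2N(Cc2ccc(-c3ccccc3CNC(N)=O)cc2)C1=O`) gives 21 nM. Compound 3 thus stands in the middle of the three, with a lower number than compound 1 and a higher number than compound 2.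

The next compound is compound 4 (`CC(C)(N)C(=O)N[C@@H]1CCc2ccccc2N(Cc2ccc(-c3ccccc3CNC(=O)NC3CC3)cc2)C1=O`), with cyclopropyl in place of hydrogen on an amide-type nitrogen.

Going by the values given here, only one measured step bears on this change: a 21-fold higher number from compound 2 to compound 3 (1.32 log units; beyond the scatter). It is large and beyond the scatter, and it concerns hydrogen in place of methyl on an amide-type nitrogen. Read in reverse, it points to a lower number when hydrogen on that nitrogen is replaced. Among the compounds with values here, no measured compound carries cyclopropyl there, so the size rests on methyl alone and stays uncertain. In this assay a sizeable step towards a lower number is expected, probably not quite as large as the methyl step. The expected step is a 5.3-fold lower number from compound 3 to compound 4 (0.72 log units; beyond the scatter). For compound 4 the estimated value is 4 nM, with an expected range from 1 nM to 15 nM.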

Compound 4, concentration for half-maximal effect: 45 nM
Compound 4: middle estimate off by 11-fold (1.05 log units), on the low side, and the stated range ends below it.
By their numbers in this assay, from the lowest: compound 2; then compound 3; then compounds 4 and 1 (each within the scatter of the next).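

In this assay, replacing hydrogen on this amide-type nitrogen does not by itself lower the number: cyclopropyl gives a 2.1-fold higher number from compound 3 to compound 4 (0.33 log units; beyond the scatter) and so runs opposite to the methyl change, for which the listed step is a 21-fold higher number from compound 2 to compound 3 (1.32 log units; beyond the scatter) in the reverse sense. The two substituents are far apart at this one position, with a 45-fold higher number from compound 2 to compound 4 (1.65 log units; beyond the scatter) separating them, so the result seen with methyl does not carry over to cyclopropyl. No available evidence bears on this difference.

With only hydrogen, methyl and cyclopropyl shown on this nitrogen, it stays open whether the low number belongs to methyl alone or extends to other small groups. Ethyl or isopropyl at this position, or a second methyl on the same nitrogen, would help to settle that.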